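The source may report more compounds than this note shows. Statements on the series, on what has been measured and on what is new or still open speak of the compounds shown alone.

Measured compounds:
compound 1 `Cc1cc(C)c2cc(C#N)c(NCCNC(=O)c3ccncc3)nc2c1` — 7300 nM
compound 2 `Cc1cc(C)c2cc(C#N)c(NCCNC(=O)c3ccccc3)nc2c1` — "not active" (no number reported)

Going by the values given here, compound 1 carries the only number here; in an in vitro assay on FRT cells with Cystic fibrosis transmembrane conductance regulator variant F508del (Homo sapiens) as the target, read by fluorescence, with a stated time of 24 h, at 37 degrees C, in the presence of a further agent that is not named here (a higher number here means that more compound is needed for the effect, a lower number that less compound is needed), compound 1 gives 7300 nM, while compound 2 is recorded as "not active" (no number reported) with no value. Compound 3 `COc1cccc(OC)c1C(=O)NCCNc1nc2cc(C)cc(C)c2cc1C#N` is not yet measured. It differs from compound 1 by 2,6-dimethoxyphenyl in place of pyridin-4-yl on a carbonyl carbon. Among the compounds with values here, no measured pair shows how such a change moves the reading, so the direction is open. The expected step from compound 1 to compound 3 in this assay is a 2.4-fold lower number from compound 1 to compound 3 (0.39 log units; beyond the scatter), a modest shift near the scatter. Compound 3 is estimated at 3000 nM, likely between 500 nM and 20000 nM.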

Compound 3, half-maximal effective concentration: 3700 nM
Compound 3: the middle estimate sits 1.2-fold (0.09 log units) below what was measured; the range from low to high includes it.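

In this assay putting 2,6-dimethoxyphenyl in place of pyridin-4-yl on a carbonyl carbon gives a 2.0-fold lower number from compound 1 to compound 3 (0.30 log units; within the scatter) and so leaves the two compounds indistinguishable. A ring of carbon only can therefore still give a number at this position, although compound 2, which also has a carbon-only ring, is recorded as not active. No measured evidence accounts for this result. The compounds shown leave open what a pyridin-3-yl group or a morpholine on the same carbonyl carbon would give in this assay.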